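Para-substituent swap on a chalcone-like boron heterocycle series

The compounds below may be only part of what the source reports. "The series", "measured", "known", "first", "only" and "open" are said of these compounds alone.

Compound 1 `O=C(/C=C/c1ccc2c(c1)B(O)OC2)c1cccs1`: 14200 nM
Compound 2 `O=C(/C=C/c1ccc2c(c1)B(O)OC2)c1ccc(F)cc1`: 2800 nM
Compound 3 `Cc1ccc(C(=O)/C=C/c2ccc3c(c2)B(O)OC3)cc1`: 10500 nM

In a functional assay on HCT-116 cells (Homo sapiens) for cytotoxicity, read by MTT assay, with a stated time of 48 h (a lower number here means a stronger inhibitor, a higher number a weaker inhibitor), compound 3 stands second highest of the three numbers: against compound 1 the gap is within the scatter, while a 3.8-fold higher number from compound 2 to compound 3 (0.57 log units; beyond the scatter) is beyond it. Compound 4 `O=C(/C=C/c1ccc2c(c1)B(O)OC2)c1ccc([N+](=O)[O-])cc1` is the next step, with nitro in place of methyl on an aromatic carbon. Within the data shown here, no measured step exchanges a methyl for a nitro; the only one touching the same position is a 3.8-fold higher number from compound 2 to compound 3 (0.57 log units; beyond the scatter), which shows that the group on this aromatic carbon can move the number by a modest amount. Compound 1 with 14200 nM and compound 3 with 10500 nM are otherwise close. A modest lowering, a 2.1-fold lower number from compound 3 to compound 4 (0.32 log units; beyond the scatter), is therefore expected, with wide uncertainty, and compound 4 is estimated at 5000 nM, between 1500 nM and 16000 nM.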

Compound 4, half-maximal inhibitory concentration: 9100 nM
For compound 4 the middle estimate is 1.8-fold (0.26 log units) below the measured one; low and high end bracket the measured number.
By their numbers in this assay, from the lowest: compound 2; then compounds 4, 3 and 1 (each within the scatter of the next).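

In this assay the step to nitro on this aromatic carbon gives a 1.2-fold lower number from compound 3 to compound 4 (0.06 log units; within the scatter) and so does not separate nitro from methyl, although the two groups differ in heavy atoms and hydrogen-bond acceptors. Against fluoro the same nitro group gives a 3.3-fold higher number from compound 2 to compound 4 (0.51 log units; beyond the scatter) and thus leaves fluoro alone among the three groups at this position in having a number set apart from the others. Nothing measured here offers an explanation for this result. As far as these compounds go, whether an amine, a carboxylic acid or a chloro group at this position would fall with fluoro or with methyl and nitro remains open.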